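Compound 3: thiomorpholin-4-yl replacing morpholin-4-yl on the thiocarbonyl

The source may report more compounds than this note shows. Statements on the series, on what has been measured and on what is new or still open speak of the compounds shown alone.

Among the measured compounds shown here, compound 2 `Cc1ccnc(/C(N)=N/NC(=S)N2CCOCC2)c1` gives 38500 nM in a functional assay on HeLa cells (Homo sapiens) for cytotoxicity, read by MTT assay, with a stated time of 72 h (a higher number here means a weaker inhibitor, a lower number a stronger inhibitor), the highest of the two numbers so far; compound 1 `N/C(=N\NC(=S)N1CCOCC1)c1ccccn1` gives 7300 nM, and the step of a 5.3-fold higher number from compound 1 to compound 2 (0.72 log units; beyond the scatter) is the only one measured. Compound 3 `Cc1ccnc(/C(N)=N/NC(=S)N2CCSCC2)c1` differs from compound 2 by thiomorpholin-4-yl in place of morpholin-4-yl on a thiocarbonyl carbon. For the measured compounds named here, no measured step bears on this exchange: the single known step concerns a methyl on an aromatic carbon and tells nothing about the ring on the thiocarbonyl carbon. A step in this assay of no size beyond the scatter is therefore expected. Compound 3 is estimated at 30000 nM, within 10000 nM to 90000 nM, meaning a 1.3-fold lower number from compound 2 to compound 3 (0.11 log units; within the scatter).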

Compound 3, half-maximal inhibitory concentration: 15500 nM
The estimate for compound 3 lay 1.9-fold (0.29 log units) above the measured number, within the range that was stated.
By their numbers in this assay, from the lowest: compound 1; then compound 3; then compound 2.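

The ring on the thiocarbonyl carbon is not silent in this assay: thiomorpholin-4-yl in place of morpholin-4-yl gives a 2.5-fold lower number from compound 2 to compound 3 (0.40 log units; beyond the scatter) on the methyl-bearing core. This position therefore responds to the exchange of ring oxygen for ring sulfur, which the methyl step could not show. No available measurement accounts for this step.

Going by these compounds, whether the same exchange holds on the core of compound 1 remains open. Also open, on these data alone, is how a piperidin-1-yl or dimethylamino group on the thiocarbonyl carbon would compare with either ring.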